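The source may report more compounds than this note shows. Statements on the series, on what has been measured and on what is new or still open speak of the compounds shown alone.

Measured so far:
- compound 1, `CCC(C)NC(=C\C(=O)/C=C/c1ccc(O)c(OC)c1)/C=C/c1ccc(O)c(OC)c1`: 85%
- compound 2, `COc1cc(/C=C/C(=O)/C=C(/C=C/c2ccc(OC(C)=O)c(OC)c2)NCC(C)C)ccc1OC(C)=O`: 104%
- compound 3, `COc1cc(/C=C/C(=O)/C=C(/C=C/c2ccc(O)c(OC)c2)NCC(C)C)ccc1O`: 83%

All three were tested in a functional assay on EA.hy 926 cells (Homo sapiens), read by fluorescence, tested at 1 uM; a lower number here means a weaker effect, a higher number a stronger effect of the compound at the concentration tested. Compound 3 and compound 1 share a core and differ only in one spot, (sec-butyl in place of isobutyl on an amine nitrogen). The step this made, a number 2 percentage points higher from compound 3 to compound 1 (within the scatter), is small enough to count as no change at all in this assay. Compound 2 has a different core; the difference between the core of compound 2 and the core of compound 3 is not broken down here. In this assay compound 2 gives the highest of the three numbers, and its distance from compound 1 and from compound 3 lies beyond the scatter.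

The unmeasured compound 4, `CCC(C)NC(=C\C(=O)/C=C/c1ccc(OC(C)=O)c(OC)c1)/C=C/c1ccc(OC(C)=O)c(OC)c1`, is built from compound 2 by the same change already seen between compound 3 and compound 1: sec-butyl in place of isobutyl on an amine nitrogen. The place of the change is described in the same words for both pairs, so it is the same change on a different core.

Within the data shown here, since the one measured example of this change, a number 2 percentage points higher from compound 3 to compound 1 (within the scatter), stayed within the scatter, the step from compound 2 to compound 4 is expected to be about as small, no change at the digits printed from compound 2 to compound 4 (within the scatter). On that basis compound 4 is estimated at 104% in this assay, most likely between 90% and 116%. This rests on a single prior example, so the expectation is loose.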

Compound 4, a percentage reported as activity, at one concentration (the size of the read-out at that concentration, not a potency): 68%
Beside the measured number, compound 4's estimate is 36 percentage points above it; the whole stated range lies above it.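

On the core that carries the two acetate esters, sec-butyl in place of isobutyl on an amine nitrogen gives a clear fall in this assay, a number 36 percentage points lower from compound 2 to compound 4 (beyond the scatter), so a swap that seemed harmless on the core with free hydroxyl groups is not harmless here. Among these compounds, the outcome of this small change between two chains of the same size therefore depends on the core it is made on, and a result from one core cannot simply be carried over to the other: the same change on two cores in this assay, a number 2 percentage points higher (within the scatter) from compound 3 to compound 1 and a number 36 percentage points lower (beyond the scatter) from compound 2 to compound 4, 38 percentage points apart, beyond the scatter of two such steps What this does not show is why the two cores respond differently, or whether the same contrast would hold for other changes on the nitrogen, as each core offers only one example of this swap.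

The compounds shown carry only two branched butyl chains on the nitrogen, so it remains open how a straight butyl chain, a longer chain or a cyclohexyl ring would behave on either core. Going by these compounds, it also remains open whether a core with methyl ethers or propionate esters in place of the acetate esters would respond to the swap like compound 2 and compound 4 or like compound 3 and compound 1.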